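This account rests on a few compounds, and the source may have more. Where it says the series, first, only, none or still open, it means among the compounds named here.

In a functional assay on SK-MEL-5 cells (Homo sapiens) (a lower number here means a stronger inhibitor of growth, a higher number a weaker inhibitor of growth), three compounds have been measured so far. Compound 1 (`COc1cccc(-c2cc(=O)c3ccc(C)nc3[nH]2)c1`) gives 33.9 nM and holds the lowest number, while compound 2 (`COc1ccc(-c2cc(O)c3c(C)cc(C)nc3n2)cc1`) gives 17800 nM and holds the highest. Compound 3 (`COc1cccc(-c2cc(O)c3c(C)cc(C)nc3n2)c1`) stands second highest of the three at 288 nM between them. Compound 4 (`COc1cccc(-c2cc(O)c3c(C)ccnc3n2)c1`) has not been measured and differs from compound 3 in one place: hydrogen in place of methyl on an aromatic carbon (hydrogen in place of methyl on an aromatic carbon, next to the ring nitrogen). For the measured compounds named here, no measured pair isolates this change, so a step within the scatter, with no clear direction, is expected. The estimated change is a 1.2-fold lower number from compound 3 to compound 4 (0.06 log units; within the scatter) on this reading. Compound 4 is estimated at 250 nM with a range from 50 nM to 1300 nM for now.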

Compound 4, concentration for 50% growth inhibition: 22.4 nM
Estimate against measurement, compound 4: 11-fold (1.05 log units) above, and the stated range ends above it.
By their numbers in this assay, from the lowest: compounds 4 and 1 (each within the scatter of the next); then compound 3; then compound 2.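

In this assay hydrogen in place of methyl on the aromatic carbon next to the ring nitrogen gives a 13-fold lower number from compound 3 to compound 4 (1.11 log units; beyond the scatter) and so lies beyond the scatter. This shows that the position is not neutral in this series: with the rest of the structure unchanged, removing this one methyl alone markedly strengthens growth inhibition. Nothing available here accounts for the size of this step.

The compounds shown leave open what ethyl, chlorine or an amine would give at this position. They also leave open whether the same change would carry over to compound 2.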